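Alkyne to alkene on a shared purine-free core, fixed in form

This account rests on a few compounds, and the source may have more. Where it says the series, first, only, none or still open, it means among the compounds named here.

Measured compounds:
compound 1, `C(#Cc1ncnc2c1ncn2C1CCOCC1)c1ccccc1`: 100%
compound 2, `C(#Cc1ncnc2c1ncn2Cc1ccccc1)c1ccccc1`: 98%
compound 3, `C(#Cc1nc(-c2ccccc2)nc2c1ncn2Cc1ccccc1)c1ccccc1`: 100%

In a functional assay on K562 cells (Homo sapiens) for inhibition, read by thymidine incorporation, with a stated time of 48 h, tested at 10 ug/mL (a higher number here means more inhibition at the concentration tested (going by the name of the read-out), a lower number less inhibition), compound 1 gives 100%, compound 2 gives 98% and compound 3 gives 100%. Compound 2 stands within the scatter of both neighbours: the step of a number 2 percentage points lower from compound 1 to compound 2 (within the scatter) and the step of a number 2 percentage points higher from compound 2 to compound 3 (within the scatter) are each too small to call a change, so the three measured compounds are indistinguishable in this assay.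

Compound 4, `C(=C/c1ncnc2c1ncn2Cc1ccccc1)\c1ccccc1`, has not yet been measured. It differs from compound 2 in one place: 2-phenylethenyl in place of 2-phenylethynyl on an aromatic carbon. Neither measured step touches this part of the structure; the step from compound 1 to compound 2 changes the group on the aromatic nitrogen, the step from compound 2 to compound 3 adds a phenyl on another aromatic carbon, and both sat within the scatter. Nothing measured therefore speaks for a large step in this assay either way, and since all three measured numbers already stand high in this assay, the most that can be expected is a small fall in the number, if any.

Compound 4 is therefore expected to give 94% in this assay, within 78% to 100%, which means an expected step of a number 4 percentage points lower from compound 2 to compound 4 (within the scatter).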

Compound 4, a percentage reported as inhibition, at one concentration (the size of the read-out at that concentration, not a potency): 93%
Estimate against measurement, compound 4: 1 percentage points above, and the stated range covers the measured number.
By their numbers in this assay, from the lowest: compounds 4, 2, 1 and 3 (each within the scatter of the next).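

In this assay, the step of a number 5 percentage points lower from compound 2 to compound 4 (within the scatter) is the first one shown that alters the link between the shared core and the terminal phenyl, since the earlier steps concerned the group on the aromatic nitrogen and a phenyl added on another aromatic carbon. With a double bond outside aromatic rings in place of the triple bond, on the aromatic carbon next to the ring nitrogen, the pair shows no difference that can be called a change in this assay, so at this concentration the read-out for this one pair does not separate 2-phenylethenyl from 2-phenylethynyl. No supporting measurement bears on this result, and the data give no account of it.

The compounds shown leave open whether 2-phenylethyl, with no multiple bond in the chain, the other geometric form of the alkene, or an amine or a carboxylic acid on this aromatic carbon would keep the number as high. They also leave open how these compounds compare in potency, as a read-out at one concentration gives only the size of the inhibition there.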